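This account rests on a few compounds, and the source may have more. Where it says the series, first, only, none or still open, it means among the compounds named here.

Measured so far:
Compound 1 `CC(C)C(Cc1ncc[nH]1)c1ccc(-c2ccc3cccc(F)c3c2)[nH]c1=O` gives 76 nM in a functional assay on CHO cells for antagonist activity at prostaglandin E2 receptor EP3 subtype (Homo sapiens), read by cAMP accumulation; on this read-out lower numbers stand for stronger inhibition and higher numbers for weaker inhibition.
Compound 2 `CCC(CC)(c1nnc[nH]1)c1ccc(-c2ccc3cccc(F)c3c2)[nH]c1=O` gives 36 nM in this assay.

Compound 1 stands at the highest of the two numbers obtained in this assay; its nearest neighbour is compound 2, whose number is lower by a margin that lies beyond the scatter of the method. The unmeasured compound 3 `Cc1nc(C(c2ccc(-c3ccc4cccc(F)c4c3)[nH]c2=O)C(C)C)[nH]c1C` is built from compound 1 by a single change: 4,5-dimethyl-1H-imidazol-2-yl in place of (1H-imidazol-2-yl)methyl on a saturated chain carbon bound to an aromatic carbon and a saturated chain carbon. For the measured compounds named here, since the two measured compounds differ from each other in more than one place, no single step between them can be read off, and the change from compound 1 to compound 3 has no direct precedent among the numbers available. The account therefore expects only a modest movement in this assay, if any, with the number for compound 3 most likely staying close to that of compound 1 and a slight lean toward a lower number. On this basis compound 3 is estimated at 50 nM in this assay, within a range from 15 nM to 200 nM, meaning a step of a 1.5-fold lower number from compound 1 to compound 3 (0.18 log units; within the scatter).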

Compound 3, half-maximal inhibitory concentration: 50 nM
Estimate against measurement, compound 3: no gap at the digits printed; measured number inside the range.
By their numbers in this assay, from the lowest: compounds 2, 3 and 1 (each within the scatter of the next, the first and the last beyond it).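

In this assay, for the compounds shown here, placing 4,5-dimethyl-1H-imidazol-2-yl where (1H-imidazol-2-yl)methyl stood gives a 1.5-fold lower number from compound 1 to compound 3 (0.18 log units; within the scatter), the first step that can be read at this saturated chain carbon, bound to an aromatic carbon and a saturated chain carbon. The earlier compounds shown here offered no such reading, and this one shows that the position accepts this exchange of one imidazole-bearing group for another with no difference beyond the scatter, while compound 2 differs from compound 1 and from compound 3 in more than one place, so steps to it cannot be read. Nothing at hand accounts for this result or connects it to any measured property of the two groups.

The step joins two alterations, the loss of the methyl link and the arrival of the two ring methyl groups, and the compounds shown hold no plain 1H-imidazol-2-yl on this carbon to separate them. They also leave open how a group of another kind, such as an amine or a carboxylic acid, would read in this place on the shared core.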